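The source may report more compounds than this note shows. Statements on the series, on what has been measured and on what is new or still open speak of the compounds shown alone.

Of the compounds shown here, three sharing one core have been measured so far in a physicochemical assay for lipophilicity, read by HPLC, at pH 7.4; a lower number here means a more polar compound, a higher number a more lipophilic compound. Compound 1 `CNCc1cc(-c2cccnc2F)n(S(=O)(=O)c2ccccc2)c1` reads -0.09 there and compound 2 `CNCc1cc(-c2cccnc2F)n(S(=O)(=O)c2cccc(F)c2)c1` reads 0.23 there, while compound 3 `CNCc1cc(-c2cccnc2F)n(S(=O)(=O)c2ccsc2)c1` stands lowest of the three at -0.83 on this scale. Compound 4 `CNCc1cc(-c2cccnc2F)n(S(=O)(=O)c2cccs2)c1` carries thiophen-2-yl in place of thiophen-3-yl on a sulfonyl sulfur. The measured steps are the closest guide: phenyl to thiophen-3-yl gave a number 0.74 log units lower from compound 1 to compound 3 (beyond the scatter) and 3-fluorophenyl to thiophen-3-yl gave a number 1.06 log units lower from compound 2 to compound 3 (beyond the scatter) while fluoro in place of hydrogen gave a number 0.32 log units higher from compound 1 to compound 2 (beyond the scatter) as a smaller change. Within the data shown here, each of those steps changes the atoms present, whereas this one keeps the same atoms joined differently, and no measured pair exchanges one thiophene for the other. Only a small shift in this assay is therefore expected, with no firm direction. The expected step is a number 0.13 log units higher from compound 3 to compound 4 (within the scatter) and so none beyond the scatter. For compound 4 the estimated value is -0.7 (expected range -1.2 to -0.2).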

Compound 4, distribution coefficient: -0.69
Estimate against measurement, compound 4: 0.01 log units below; measured number inside the range.
By their numbers in this assay, from the lowest: compounds 3 and 4 (each within the scatter of the next); then compound 1; then compound 2.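

In this assay the exchange of thiophen-3-yl for thiophen-2-yl on a sulfonyl sulfur gives a number 0.14 log units higher from compound 3 to compound 4 (within the scatter) and so does not separate the two compounds: how the thiophene is joined does not register here. The phenyl compounds stand apart from this new thiophene too, with a number 0.60 log units lower from compound 1 to compound 4 (beyond the scatter) and a number 0.92 log units lower from compound 2 to compound 4 (beyond the scatter) as the steps, so the earlier drop is not special to thiophen-3-yl. No supporting measurement explains these numbers.

Going by these compounds, how a pyridine ring or a short alkyl chain on the sulfonyl sulfur would read stays open, as does whether the two thiophenes stay level once they carry a chloro or methyl group.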